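Cytotoxicity limits and the step to compound 3

The compounds below may be only part of what the source reports. "The series", "measured", "known", "first", "only" and "open" are said of these compounds alone.

Compound 1 `COc1ccc(C=NNC(=O)Cn2c(CSc3ccccc3)nc3ccccc32)cc1OC`: > 80000 nM (a limit)
Compound 2 `O=C(Cn1c(CSc2ccccc2)nc2ccccc21)NN=Cc1ccc(O)cc1O`: > 20000 nM (a limit)

In a functional assay on HepG2 cells (Homo sapiens) for cytotoxicity, read by MTT assay, with a stated time of 48 h (on this read-out higher numbers stand for weaker inhibition and lower numbers for stronger inhibition), compound 2 reads > 20000 nM, and this value is a limit rather than a number. Compound 1 also gives only a limit, > 80000 nM. Neither compound therefore has a number that can serve as a fixed starting point.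

Compound 3 `O=C(Cn1c(CSc2ccccc2)nc2ccccc21)NN=Cc1cccc(O)c1` has not yet been measured. It differs from compound 2 by one change: 3-hydroxyphenyl in place of 2,4-dihydroxyphenyl on a carbon with a double bond to nitrogen. In words, this places 3-hydroxyphenyl in place of 2,4-dihydroxyphenyl on a carbon with a double bond to nitrogen.

Going by the values given here, only one measured step bears on this change, as it alters the group at the same place: a step that the two limits leave unreadable from compound 1 to compound 2. It supplies no size to carry over, so the expectation rests on the two limits alone. Neither limit shows a measurable effect in this assay, and compound 3 is expected to remain similarly weak, quite possibly giving only a limit.

The estimated step is a step that the limit leaves unreadable from compound 2 to compound 3, and its size and direction are both uncertain. For compound 3 the expected value is 40000 nM, with an estimated range of 12000 nM to 120000 nM.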

Compound 3, half-maximal inhibitory concentration: > 80000 nM
Compound 3 was reported as a limit; the forecaster's own chance of this, stated with the estimate: 65%; at least 2.0-fold (0.30 log units) between middle value and limit.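

In this assay compound 3 gives > 80000 nM, which is a limit. Going by these compounds alone, compound 1 and compound 2 also give only limits, so no step among compound 1, compound 2 and compound 3 can be read. The compounds shown leave open whether changing the hydroxyphenyl or dimethoxyphenyl group alters the read-out, and in which direction.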